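The source may hold more compounds than are shown below. What is called first, only, known or untested is meant among the compounds shown, and "the series" means these compounds.

For the measured compounds named here, compound 3 `Cc1cc(/C=C2\SC(=S)N(Cc3ccc(C(=O)O)cc3)C2=O)c(C)n1-c1ccc(O)c(C(=O)O)c1` gives 105000 nM in an ADME assay on MT2 cells (Homo sapiens) for cytotoxicity, read by XTT assay, with a stated time of 4 days (on this read-out higher numbers stand for lower toxicity in this test and lower numbers for higher toxicity in this test), the lowest of the two numbers measured so far. Compound 2 `Cc1cc(/C=C2\SC(=S)N(Cc3ccccc3)C2=O)c(C)n1-c1ccc(O)c(C(=O)O)c1` gives 159000 nM in this assay, and the step of a 1.5-fold lower number from compound 2 to compound 3 (0.18 log units; within the scatter) is within the scatter. For compound 1 `Cc1cc(/C=C2\SC(=S)N(c3ccccc3)C2=O)c(C)n1-c1ccc(O)c(C(=O)O)c1` this assay returns only a limit, (the limit of > 100000 nM in this assay, at which 1 of the 3 values shown sits); in this assay compound 1 gives > 100000 nM. The steps a step that the limit leaves unreadable from compound 1 to compound 2 and a step that the limit leaves unreadable from compound 1 to compound 3 cannot be sized. Compound 4 `Cc1cc(/C=C2\SC(=S)N(Cc3cccc(C(F)(F)F)c3)C2=O)c(C)n1-c1ccc(O)c(C(=O)O)c1` differs from compound 3 by 3-(trifluoromethyl)phenyl in place of 4-carboxyphenyl on a saturated chain carbon bound to an amide-type nitrogen in a ring. Going by the values given here, only the step from compound 2 to compound 3 bears on this, through the carboxy, and it was within the scatter; no measured step covers the trifluoromethyl. The expectation for compound 4 is therefore no step beyond the scatter, a 1.1-fold lower number from compound 3 to compound 4 (0.02 log units; within the scatter). Compound 4 is estimated at 100000 nM, between 40000 nM and 250000 nM.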

Compound 4, half-maximal cytotoxic concentration: 26300 nM
Compound 4: the middle estimate sits 3.8-fold (0.58 log units) above what was measured; measured number outside the range, below it.
By their numbers in this assay, from the lowest: compound 4; then compounds 3 and 2 (each within the scatter of the next).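

In this assay, the benzyl group now shows a change beyond the scatter, which the carboxy step had not: a 4.0-fold lower number from compound 3 to compound 4 (0.60 log units; beyond the scatter), and a 6.0-fold lower number from compound 2 to compound 4 (0.78 log units; beyond the scatter). Among the compounds shown, the trifluoromethyl group is the only substituent on the benzyl group that gives a readable rise in toxicity in this test. The step of an at least 3.8-fold lower number from compound 1 to compound 4 (0.58 log units; beyond the scatter) starts from a limit: the limit of > 100000 nM in this assay, at which 1 of the 4 values shown sits.

On these data alone, whether a chloro, nitrile or methoxy group in place of the trifluoromethyl gives a similarly low number remains open.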